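From 2-bromo-5-ethoxyphenyl to 4-fluorophenyl

This account rests on a few compounds, and the source may have more. Where it says the series, first, only, none or still open, it means among the compounds named here.

- Compound 1 `Cc1oc2c([C@H]3CCN(C)C[C@H]3O)c(O)cc(O)c2c(=O)c1C(O)c1c(F)cccc1Cl`: 49%
- Compound 2 `CCOc1ccc(Br)c(C(O)c2c(C)oc3c([C@H]4CCN(C)C[C@H]4O)c(O)cc(O)c3c2=O)c1`: 2%

In a functional assay on HL-60 cells (Homo sapiens) for inhibition, read by MTT assay, with a stated time of 48 h, tested at 10 uM (a higher number here means more inhibition of growth at the concentration tested, a lower number less inhibition of growth), compound 2 stands at 2%, the lower of the two numbers, while compound 1 gives 49%. Compound 3 `Cc1oc2c([C@H]3CCN(C)C[C@H]3O)c(O)cc(O)c2c(=O)c1C(O)c1ccc(F)cc1` is the next to be measured. It carries 4-fluorophenyl in place of 2-bromo-5-ethoxyphenyl on a saturated chain carbon bound to an aromatic carbon and an oxygen on a saturated carbon.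

Going by the values given here, one measured step bears on this change, at the same place: a number 47 percentage points lower from compound 1 to compound 2 (beyond the scatter). That step is large, so the group at this place can clearly matter, but neither measured compound carries 4-fluorophenyl. Like compound 1, compound 3 has a fluorine-bearing phenyl group and no ethoxy group, so a rise of moderate to large size is expected, with wide uncertainty. The expected change is a number 26 percentage points higher from compound 2 to compound 3 (beyond the scatter). The estimated value of compound 3 is 28%, with an expected range from 6% to 55%.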

Compound 3, percent growth inhibition at one concentration: 30%
For compound 3 the middle estimate is 2 percentage points below the measured one; measured number inside the range.
By their numbers in this assay, from the lowest: compound 2; then compound 3; then compound 1.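

In this assay, this position now gives three separate levels rather than two: a number 28 percentage points higher from compound 2 to compound 3 (beyond the scatter), while a number 19 percentage points lower from compound 1 to compound 3 (beyond the scatter). The change to 4-fluorophenyl therefore restores part, but not all, of the growth inhibition seen with 2-chloro-6-fluorophenyl, which shows that the group at this place can grade the result and does not simply switch it on or off. Compound 1 and compound 3 both carry a fluorine-bearing phenyl group yet remain apart, so fluorine on the phenyl group does not alone set the level, and nothing available explains why the three groups fall in this order.

Going by these compounds, the three groups differ in several features at once, so it remains open whether the bromine or the ethoxy group goes with the low number of compound 2, and whether the chlorine of compound 1 goes with its higher number than that of compound 3. On these data alone, it is also open what a phenyl group carrying an amine or a carboxylic acid would give at this place.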